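Swapping the aryl group on the sulfonamide of compound 3

The source may hold more compounds than are shown below. What is called first, only, known or untested is meant among the compounds shown, and "the series" means these compounds.

Measured so far:
- compound 1 `O=C(Nc1cccc(/C=C/C(=O)c2nc3ccccc3[nH]2)c1)c1ccccc1` gives 11200 nM in a functional assay on MCF7 cells (Homo sapiens) for antiproliferative activity, read by MTT assay, with a stated time of 48 h; on this read-out higher numbers stand for weaker inhibition and lower numbers for stronger inhibition
- compound 2 `O=C(Nc1cccc(/C=C/C(=O)c2nc3ccccc3[nH]2)c1)c1ccc(Cl)cc1` gives 8410 nM in this assay
- compound 3 `O=C(/C=C/c1cccc(NS(=O)(=O)c2ccccc2Cl)c1)c1nc2ccccc2[nH]1` gives 4280 nM in this assay

For the measured compounds named here, compound 3 holds the lowest of the three numbers, but its gap to compound 2 lies within the scatter, and only the step of a 2.6-fold lower number from compound 1 to compound 3 (0.42 log units; beyond the scatter) is beyond it, so compound 3 cannot be called the strongest of the set. Compound 4 `O=C(/C=C/c1cccc(NS(=O)(=O)c2cc(Cl)cc(Cl)c2)c1)c1nc2ccccc2[nH]1` differs from compound 3 in one place: 3,5-dichlorophenyl in place of 2-chlorophenyl on a sulfonyl sulfur. The measured steps touch this change only at a distance. The step of a 1.3-fold lower number from compound 1 to compound 2 (0.12 log units; within the scatter) shows a chloro entering on an aromatic carbon of a different group and staying within the scatter. The steps of a 2.0-fold lower number from compound 2 to compound 3 (0.29 log units; within the scatter) and a 2.6-fold lower number from compound 1 to compound 3 (0.42 log units; beyond the scatter) concern the swap of carbonyl for sulfonyl, not the pattern of chloro groups on the aryl ring. Going by the values given here, no pair shows a second chloro or a shift of one. The step of a 1.1-fold lower number from compound 3 to compound 4 (0.05 log units; within the scatter) is therefore expected to stay within the scatter. Compound 4 is estimated at 3800 nM in this assay, with a range from 1500 nM to 9500 nM.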

Compound 4, half-maximal inhibitory concentration: 20000 nM
For compound 4 the middle estimate is 5.3-fold (0.72 log units) below the measured one, outside the stated range (above it).
By their numbers in this assay, from the lowest: compounds 3, 2, 1 and 4 (each within the scatter of the next, the first and the last beyond it).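

On the sulfonyl sulfur, the pattern of chloro groups on the aryl ring makes a measurable difference: 3,5-dichlorophenyl in place of 2-chlorophenyl gives a 4.7-fold higher number from compound 3 to compound 4 (0.67 log units; beyond the scatter) in this assay. The earlier compounds shown here showed only a chloro entering on a different group and the swap of carbonyl for sulfonyl, whereas here the aryl group on the sulfonyl sulfur changes alone and the change goes towards weaker inhibition. Nothing shown accounts for this step.

The compounds shown leave open how much of the step belongs to the added chloro and how much to the changed pattern, as both change together in this single pair. They also leave open how a plain phenyl, or an aryl ring carrying an amine or a carboxylic acid, would stand on that sulfonyl sulfur.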